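Two sulfonamide heteroaryl swaps on a shared core

This account rests on a few compounds, and the source may have more. Where it says the series, first, only, none or still open, it means among the compounds named here.

Measured compounds:
- compound 1, `Nc1ccc(S(=O)(=O)Nc2ccnc3cc(C(F)(F)F)ccc23)cc1`: 46000 nM
- compound 2, `NS(=O)(=O)c1ccc(N/C(S)=N\c2ccnc3cc(C(F)(F)F)ccc23)cc1`: 36600 nM
- compound 3, `Cc1noc(NS(=O)(=O)c2ccc(N/C(S)=N\c3ccnc4cc(C(F)(F)F)ccc34)cc2)c1C`: "not active" (no number reported)

In a functional assay on HeLa cells (Homo sapiens) for antiproliferative activity, read by sulforhodamine B assay, with a stated time of 48 h (a higher number here means a weaker inhibitor, a lower number a stronger inhibitor), compound 1 gives 46000 nM and compound 2 gives 36600 nM; these two values lie within the usual scatter of each other. Compound 3 stands apart only in that it gives "not active" (no number reported) in this assay, so no single number describes it.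

Compound 4, `O=S(=O)(Nc1ncccn1)c1ccc(N/C(S)=N\c2ccnc3cc(C(F)(F)F)ccc23)cc1`, differs from compound 3 in one place: pyrimidin-2-yl in place of 3,4-dimethyl-1,2-oxazol-5-yl on a sulfonamide nitrogen. Both groups are small aromatic rings with two hetero atoms and two hydrogen-bond acceptors, one five-membered and one six-membered. Among the measured compounds shown here, no measured pair shows this kind of exchange, so the size and direction of the step cannot be read from the data. The closest guide is that all three measured compounds are weak or inactive in this assay. Compound 4 is therefore expected to remain weak, and its value is estimated at 50000 nM, within a range from 15000 nM to 200000 nM, with a fair chance that only a limit is reported.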

Compound 4, half-maximal inhibitory concentration: "not active" (no number reported)
Nothing numeric was reported for compound 4, so the estimate cannot be set against anything.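

Compound 3 and compound 4 are both reported as not active, without a number, so no step between them can be read, and nothing measured here offers an explanation.

As far as these compounds go, whether exchanging 3,4-dimethyl-1,2-oxazol-5-yl for pyrimidin-2-yl changes activity at all remains open.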